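Fluoro added to the hydroxyphenyl arm of compound 3

This account rests on a few compounds, and the source may have more. Where it says the series, first, only, none or still open, it means among the compounds named here.

Three members of the series have numbers in a functional assay on A549 cells (Homo sapiens) for cytotoxicity, read by MTT assay, with a stated time of 72 h; on this read-out higher numbers stand for weaker inhibition and lower numbers for stronger inhibition. Compound 1 `CN(C)CCn1cnnc1-c1cc(Oc2ccc(NC(=O)N/N=C/c3ccccc3O[N+](=O)[O-])cc2F)ccn1` carries a 2-(nitrooxy)phenyl on the carbon with a double bond to nitrogen and gives 1200 nM. Compound 3 `CN(C)CCn1cnnc1-c1cc(Oc2ccc(NC(=O)N/N=C/c3ccc(O)cc3)cc2F)ccn1` carries a 4-hydroxyphenyl there and gives 3560 nM, the higher of the two numbers measured, with a 3.0-fold higher number from compound 1 to compound 3 (0.47 log units; beyond the scatter). Compound 2 `COc1cc(/C=N/NC(=O)Nc2ccc(Oc3ccnc(-c4nncn4CCN(C)C)c3)c(F)c2)cc(OC)c1OC` carries a 3,4,5-trimethoxyphenyl, and its result is only a limit of this assay, > 100000 nM, see (the limit of > 100000 nM in this assay, at which 1 of the 3 values shown sits); from this follow an at least 83-fold higher number from compound 1 to compound 2 (1.92 log units; beyond the scatter) and an at least 28-fold lower number from compound 2 to compound 3 (1.44 log units; beyond the scatter).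

Compound 4 `CN(C)CCn1cnnc1-c1cc(Oc2ccc(NC(=O)N/N=C/c3ccc(O)c(F)c3)cc2F)ccn1` differs from compound 3 by fluoro in place of hydrogen on an aromatic carbon. Among the measured compounds shown here, no measured step exchanges a single substituent on this aryl; the three steps above swap the whole aryl and show that this assay reacts strongly to that part, but they say nothing about a fluoro entering ortho to a hydroxy group while the 4-hydroxyphenyl pattern is kept. For the measured compounds named here, with no step to lean on, no shift beyond the scatter is expected, and the estimate for compound 4 is 3000 nM, between 1200 nM and 8000 nM. The expected step is a 1.2-fold lower number from compound 3 to compound 4 (0.07 log units; within the scatter).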

Compound 4, half-maximal inhibitory concentration: 13400 nM
For compound 4 the middle estimate is 4.5-fold (0.65 log units) below the measured one, and the stated range ends below it.
By their numbers in this assay, from the lowest: compound 1; then compound 3; then compound 4. At a limit, above all of these: compound 2.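

In this assay the aryl arm responds to a single added atom and not only to a swap of the whole aryl: fluoro in place of hydrogen, ortho to a hydroxy group, gives a step beyond the scatter (a 3.8-fold higher number from compound 3 to compound 4 (0.58 log units; beyond the scatter)). With this change the 3-fluoro-4-hydroxyphenyl arm lies further from the 2-(nitrooxy)phenyl arm (an 11-fold higher number from compound 1 to compound 4 (1.05 log units; beyond the scatter)) yet stays apart from the 3,4,5-trimethoxyphenyl arm (an at least 7.4-fold lower number from compound 2 to compound 4 (0.87 log units; beyond the scatter)), so the order of the arms is compound 1, compound 3, compound 4, with compound 2 last. The step from compound 2 rests on a limit and not on a number: the limit of > 100000 nM in this assay, at which 1 of the 4 values shown sits.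

From the compounds shown here alone, whether the rise belongs to fluoro itself or to any substituent at this place remains open, and chloro, methyl or methoxy on the same aromatic carbon would separate the two readings. Also open, going by these compounds, is whether the fluoro step depends on the hydroxy group, which a methoxy group in place of that hydroxy group, with the fluoro kept, would test.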